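A few compounds are considered here, and "the series" means these few. Any claim that something is new, unique, unknown or untested is made for them only; others in the source may bear on it.

Compound 1, `CNc1cc(Oc2ccc(NC(=O)Nc3cccc(C)c3)cc2)ncn1`, gives 1260 nM.
Compound 2, `CNc1cc(Oc2ccc(NC(=O)Nc3cccc(C(F)(F)F)c3)cc2)ncn1`, gives 40 nM.
Compound 3, `CNc1cc(Oc2ccc(NC(=O)Nc3cccc(C(C)(C)C)c3)cc2)ncn1`, gives 40 nM.

These three numbers come from an assay on isolated protein for inhibition of serine/threonine-protein kinase TNNI3K (Homo sapiens); on this read-out higher numbers stand for weaker inhibition and lower numbers for stronger inhibition. On them, compound 2 stands level with compound 3, the two sharing the lowest value, and it is far from compound 1, which shows a 32-fold lower number from compound 1 to compound 2 (1.50 log units; beyond the scatter). Compound 3 shows the same kind of gap, a 32-fold lower number from compound 1 to compound 3 (1.50 log units; beyond the scatter), while between the two close compounds there is no change at the digits printed from compound 2 to compound 3 (within the scatter).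

Compound 4, `O=C(Nc1ccc(Oc2cc(NCCO)ncn2)cc1)Nc1cccc(C(F)(F)F)c1`, has not yet been measured. For the measured compounds named here, its only difference from compound 2 is hydroxymethyl in place of hydrogen on a saturated chain carbon bound to a nitrogen on an aromatic ring, so the methylamino becomes (2-hydroxyethyl)amino. Going by the values given here, none of the measured steps touches this part of the structure: all three concern the group on the aromatic carbon at the other end, where compound 2 already carries the trifluoromethyl that is kept in compound 4. Among the compounds with values here, there is therefore no measured step to lean on, and the expectation is a step of about a 1.3-fold higher number from compound 2 to compound 4 (0.10 log units; within the scatter), not beyond the scatter, in either direction. Compound 4 is estimated at 50 nM, with a range from 15 nM to 160 nM.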

Compound 4, half-maximal inhibitory concentration: 32 nM
For compound 4 the middle estimate is 1.6-fold (0.19 log units) above the measured one; measured number inside the range.
By their numbers in this assay, from the lowest: compounds 4, 2 and 3 (each within the scatter of the next); then compound 1.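

For the compounds shown here, the earlier steps all concerned the group on the aromatic carbon, which compound 2 and compound 4 share, so this is the first step to touch the methylamino. Replacing it with (2-hydroxyethyl)amino gives a 1.3-fold lower number from compound 2 to compound 4 (0.10 log units; within the scatter) and shows that this position accepts a hydroxymethyl on the saturated chain carbon bound to a nitrogen on an aromatic ring with no shift that stands out from the scatter of repeat measurements. No measurement at hand bears on why the number holds here.

Going by these compounds, a single pair cannot show how far this acceptance extends, so a longer chain such as 3-hydroxypropyl, an amine such as 2-aminoethyl, or a carboxylic acid at this position remains open. On these data alone, it is also open whether (2-hydroxyethyl)amino would behave the same with tert-butyl in place of trifluoromethyl.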